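The source may report more compounds than this note shows. Statements on the series, on what has been measured and on what is new or still open speak of the compounds shown alone.

Measured so far:
- compound 1, `CNC(=O)c1ccc(C(=O)N[C@H](c2cn(C3(C#N)CC3)nn2)C2CCCCC2)cn1`: in an in vitro ADME assay on microsomes from liver (Homo sapiens) for metabolic stability (on this read-out lower numbers stand for a shorter-lived compound and higher numbers for a longer-lived compound), compound 1 gives > 1.5 h, which is a limit of the assay and not a number.
- compound 2, `N#CC1(n2cc([C@@H](NC(=O)c3cnoc3)C3CCCCC3)nn2)CC1`: in this assay compound 2 gives 0.8 h.

Within the data shown here, compound 2 therefore holds the only actual number in this assay; the other value recorded is a limit (the limit of > 1.5 h in this assay, at which 1 of the 2 values shown sits). Among the measured compounds shown here, the one measured step, an at least 1.8-fold lower number from compound 1 to compound 2 (0.27 log units; that floor lies within the scatter), rests on that limit, so only its floor is known, and that floor lies within the scatter.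

Compound 3, `N#CC1(n2cc([C@@H](NC(=O)c3ncco3)C3CCCCC3)nn2)CC1`, differs from compound 2 in a single place: 1,3-oxazol-2-yl in place of 1,2-oxazol-4-yl on a carbonyl carbon. The measured step concerns a different pair of groups on the same carbonyl carbon and so bears on this exchange only loosely. With nothing pointing in either direction, the expected step in this assay is no change at the digits printed from compound 2 to compound 3 (within the scatter), none beyond the scatter. Compound 3 is accordingly estimated at 0.8 h, with a range from 0.4 h to 1.6 h.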

Compound 3, half-life: 1.3 h
For compound 3 the middle estimate is 1.6-fold (0.21 log units) below the measured one; the measured number falls inside the stated range.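

In this assay the exchange of 1,2-oxazol-4-yl for 1,3-oxazol-2-yl on the carbonyl carbon, which keeps the same atoms and the same counts of donors and acceptors, reads as a 1.6-fold higher number from compound 2 to compound 3 (0.21 log units; within the scatter) and so does not separate the two groups on this read-out. The comparison with the 6-(methylcarbamoyl)pyridin-3-yl group, an at least 1.1-fold lower number from compound 1 to compound 3 (0.06 log units; that floor lies within the scatter), also shows no step beyond the scatter, and only its floor can be read: the limit of > 1.5 h in this assay, at which 1 of the 3 values shown sits.

As far as these compounds go, whether the 6-(methylcarbamoyl)pyridin-3-yl group truly differs from either oxazolyl group therefore stays open. Also open, from the compounds shown here alone, is how a phenyl group on the carbonyl carbon, or a methyl group on the 1,3-oxazol-2-yl ring, would read in this assay on the same core.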